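The source may hold more compounds than are shown below. What is called first, only, known or untested is meant among the compounds shown, and "the series" means these compounds.

Measured in a functional assay on A549 cells (Homo sapiens) for inhibition, read by sulforhodamine B assay, with a stated time of 72 h; a higher number here means a weaker inhibitor, a lower number a stronger inhibitor
compound 1 `Nc1sc(-c2ccc(Cl)cc2)c(-c2ccc(Cl)cc2)c1C(=O)NC1CCC(O)CC1` gives 250 nM
compound 2 `CC(C)CNC(=O)c1c(N)sc(-c2ccc(Cl)cc2)c1-c1ccc(Cl)cc1` gives 21000 nM
compound 3 `Nc1sc(-c2ccc(Cl)cc2)c(-c2ccc(Cl)cc2)c1C(=O)N1CCC(=O)CC1=O` gives 4090 nM

Compound 3 holds the middle place of the three numbers, weaker than compound 1 and stronger than compound 2. Next is compound 4 `Nc1sc(-c2ccc(Cl)cc2)c(-c2ccc(Cl)cc2)c1C(=O)N1CCNCC1`, with piperazin-1-yl in place of 2,4-dioxopiperidin-1-yl on a carbonyl carbon at the same place.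

Two measured steps change this place: the large 16-fold higher number from compound 1 to compound 3 (1.21 log units; beyond the scatter) and the modest 5.1-fold lower number from compound 2 to compound 3 (0.71 log units; beyond the scatter). The large 84-fold higher number from compound 1 to compound 2 (1.92 log units; beyond the scatter) shows a further change on the amide nitrogen. Within the data shown here, the number therefore moves far with changes here, yet no measured step exchanges one ring for another. Both compounds join the carbonyl carbon through a ring nitrogen, so no step beyond the scatter is expected in this assay, with wide uncertainty. The expected step is a 1.4-fold lower number from compound 3 to compound 4 (0.13 log units; within the scatter) on this reasoning. Compound 4 is estimated at 3000 nM in this measurement, with an expected range from 500 nM to 15000 nM here.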

Compound 4, half-maximal inhibitory concentration: 1020 nM
For compound 4 the middle estimate is 2.9-fold (0.47 log units) above the measured one, within the range that was stated.
By their numbers in this assay, from the lowest: compound 1; then compound 4; then compound 3; then compound 2.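

In this assay, exchanging one ring for another on the carbonyl carbon does move the number, a 4.0-fold lower number from compound 3 to compound 4 (0.60 log units; beyond the scatter), so amides joined through a ring nitrogen are not interchangeable at this place. The piperazin-1-yl amide lies far from the isobutylamino amide, a 21-fold lower number from compound 2 to compound 4 (1.31 log units; beyond the scatter), but short of the (4-hydroxycyclohexyl)amino amide, a 4.1-fold higher number from compound 1 to compound 4 (0.61 log units; beyond the scatter), which stays the strongest of the four. No measurement at hand explains the effect of this ring exchange.

The compounds shown leave open whether the difference follows the second ring nitrogen of piperazin-1-yl, which a morpholin-4-yl or 4-methylpiperazin-1-yl amide would test. They also leave open how much of the standing of compound 1 rests on its hydroxyl rather than its cyclohexyl ring, which a plain cyclohexylamino amide would separate.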